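The compounds below may be only part of what the source reports. "The series", "measured", "known", "first", "only" and "open" are said of these compounds alone.

Among the compounds with values here, compound 3, `CCc1ccc(-c2cn3ccnc3c(-c3ccc4ncn(Cc5ccccc5)c4c3)n2)cc1`, is one of three compounds measured in a functional assay on MDA-MB-231 cells (Homo sapiens) for inhibition, read by sulforhodamine B assay, with a stated time of 48 h, tested at 10 uM (on this read-out lower numbers stand for less inhibition and higher numbers for more inhibition at the one concentration tested (going by the name of the read-out)), where compound 3 gives 43.2%. On these numbers compound 3 stands second highest. Its nearest neighbour is compound 1, `O=Cc1ccc(-c2cn3ccnc3c(-c3ccc4ncn(C5CCCCC5)c4c3)n2)cc1`, which in this assay gives 51.2%, a value within the scatter of compound 3. The furthest is compound 2, `CC(=O)c1ccc(-c2cn3ccnc3c(-c3ccc4ncn(C5CCCCC5)c4c3)n2)cc1`, which gives 7.65%, well beyond the scatter below compound 3.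

Within the data shown here, only one single-point step is available among the measured compounds: a number 43.6 percentage points lower from compound 1 to compound 2 (beyond the scatter). That step exchanges a hydrogen for a methyl on a carbonyl carbon and says nothing directly about a change of the aryl group.

Compound 4, `c1ccc(Cn2cnc3ccc(-c4nc(-c5cccc6ccccc56)cn5ccnc45)cc32)cc1`, differs from compound 3 in one place: naphthalen-1-yl in place of 4-ethylphenyl on an aromatic carbon. Among the measured compounds shown here, no measured step concerns this kind of exchange, so there is no basis in the data for expecting a change in either direction beyond the scatter. Compound 4 is therefore expected to give a value close to that of compound 3, estimated at 40% with a range from 15% to 65%. For the measured compounds named here, the expected step is a number 3.2 percentage points lower from compound 3 to compound 4 (within the scatter), with wide uncertainty because the only measured step, a number 43.6 percentage points lower from compound 1 to compound 2 (beyond the scatter), shows how large a single change can be.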

Compound 4, a percentage reported as inhibition, at one concentration (the size of the read-out at that concentration, not a potency): 28.7%
Estimate against measurement, compound 4: 11.3 percentage points above, and the stated range covers the measured number.
By their numbers in this assay, from the lowest: compound 2; then compound 4; then compounds 3 and 1 (each within the scatter of the next).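

Within the data shown here, the exchange of 4-ethylphenyl for naphthalen-1-yl is the first measured change of the aryl group at this position, on the aromatic carbon next to the ring nitrogen, and in this assay it appears as a number 14.5 percentage points lower from compound 3 to compound 4 (beyond the scatter), a modest step that lies beyond the scatter. This shows that the read-out responds to the group at this carbon, even though the two groups are both made of carbon only and neither has hydrogen-bond donors or acceptors; the second six-membered aromatic ring does not abolish inhibition, as compound 4 still gives 28.7% at the one concentration tested. No measured evidence bears on why the number falls with this exchange.

The compounds shown do not separate the loss of the ethyl group from the gain of the second ring, a question that a plain phenyl or a naphthalen-2-yl at the same carbon would address. Also open, from the compounds shown here alone, is how a ring carrying an amine or a carboxylic acid would read at this position, and whether the same exchange would give a similar step with the cyclohexyl group of compound 1 in place.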